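Thioether chain variation on the selenium-containing triazole series

A few compounds are considered here, and "the series" means these few. Any claim that something is new, unique, unknown or untested is made for them only; others in the source may bear on it.

Measured compounds:
- compound 1, `CCCCSc1n[nH]c(-n2[se]c3ccccc3c2=O)n1`: 16800 nM
- compound 2, `CCSc1n[nH]c(-n2[se]c3ccccc3c2=O)n1`: 10000 nM
- compound 3, `CC(C)CSc1n[nH]c(-n2[se]c3ccccc3c2=O)n1`: 35000 nM

In a functional assay on SMMC-7721 cells (Homo sapiens) for antiproliferative activity, read by CCK-8 assay, with a stated time of 48 h (a higher number here means a weaker inhibitor, a lower number a stronger inhibitor), compound 3 gives the highest number of the three measured compounds and is the weakest inhibitor of them; the steps to the other two, a 2.1-fold higher number from compound 1 to compound 3 (0.32 log units; beyond the scatter) and a 3.5-fold higher number from compound 2 to compound 3 (0.54 log units; beyond the scatter), both lie beyond the scatter. Between the two straight-chain compounds the step of a 1.7-fold lower number from compound 1 to compound 2 (0.23 log units; within the scatter) lies within the scatter.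

Compound 4, `CCCCCCSc1n[nH]c(-n2[se]c3ccccc3c2=O)n1`, is not yet measured. It differs from compound 3 by pentyl in place of isopropyl on a saturated chain carbon bound to a sulfur. Both steps into compound 3, from propyl and from methyl, went to higher numbers; the step to compound 4 undoes the branching and lengthens the straight chain, which on the numbers from compound 1 and compound 2 is expected to bring the value back toward the straight-chain compounds. A modest step down, a 1.8-fold lower number from compound 3 to compound 4 (0.24 log units; within the scatter), is expected. Compound 4 is estimated at 20000 nM in this assay, with a range from 8000 nM to 50000 nM.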

Compound 4, half-maximal inhibitory concentration: 22400 nM
Compound 4: middle estimate off by 1.1-fold (0.05 log units), on the low side, within the range that was stated.
By their numbers in this assay, from the lowest: compounds 2, 1, 4 and 3 (each within the scatter of the next, the first and the last beyond it).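

In this assay the hexyl chain of compound 4 does not separate from the branched isobutyl chain of compound 3, with a 1.6-fold lower number from compound 3 to compound 4 (0.19 log units; within the scatter) leaving the two unresolved. Along the straight chains, a 1.3-fold higher number from compound 1 to compound 4 (0.12 log units; within the scatter) also stays unresolved, whereas a 2.2-fold higher number from compound 2 to compound 4 (0.35 log units; beyond the scatter) clears the scatter as a modest move toward weaker inhibition, so a difference appears only across the wider span of chain length, and compound 1 cannot be separated from either end. No measurement bearing on the reason for these steps is available.

As far as these compounds go, whether a chain longer than hexyl continues this drift or levels off remains open. Also open, from the compounds shown here alone, is whether a terminal hydroxyl or amine on the chain, or a benzyl group on the sulfur, would move the value away from this range.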